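The source may report more compounds than this note shows. Statements on the series, on what has been measured and on what is new or still open speak of the compounds shown alone.

Compound 1 `CCCCCNc1nc(N)c2nc(O)n(Cc3ccccc3)c2n1` is one of three compounds tested in a functional assay on the whole organism for activation, with Mus musculus as the target; on this read-out higher numbers stand for an effect only at larger amounts of compound and lower numbers for an effect already at smaller amounts. In this assay compound 1 gives 0.3 mg/kg, and compound 2 `CCCCCOc1nc(N)c2nc(O)n(Cc3ccccc3)c2n1` gives 0.3 mg/kg; the two stand level, together the lowest numbers of the set, and the step of no change at the digits printed from compound 1 to compound 2 (within the scatter) lies within the scatter. Compound 3 `Nc1ncnc2c1nc(O)n2Cc1ccccc1`, which carries only a hydrogen at the same aromatic carbon, gives 30 mg/kg, and the steps of a 100-fold higher number from compound 1 to compound 3 (2.00 log units; beyond the scatter) and a 100-fold higher number from compound 2 to compound 3 (2.00 log units; beyond the scatter) are both large and beyond the scatter.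

Compound 4 `CCCCCSc1nc(N)c2nc(O)n(Cc3ccccc3)c2n1` has not yet been measured. It differs from compound 1 in one place: pentylsulfanyl in place of pentylamino on an aromatic carbon. The measured steps bearing on this change are the pair just described. Removing the pentyl-bearing group altogether costs a great deal, as seen from compound 1 to compound 3, whereas exchanging pentylamino for pentyloxy changes nothing within the scatter. A pentylsulfanyl group keeps the same five-carbon chain attached through a single heteroatom, so the expectation is that compound 4 behaves like compound 1 and compound 2, with no step beyond the scatter: the expected step is no change at the digits printed from compound 1 to compound 4 (within the scatter). Compound 4 is therefore estimated at 0.3 mg/kg in this assay, with a likely range from 0.1 mg/kg to 1 mg/kg.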

Compound 4, minimum effective dose: 1 mg/kg
For compound 4 the middle estimate is 3.3-fold (0.52 log units) below the measured one; measured number inside the range.
By their numbers in this assay, from the lowest: compounds 1 and 2 (each within the scatter of the next); then compound 4; then compound 3.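

The position turns out not to be indifferent to the atom that joins the pentyl chain to the shared core: in this assay the earlier exchange of pentylamino for pentyloxy left no change beyond the scatter, whereas pentylsulfanyl gives a 3.3-fold higher number from compound 1 to compound 4 (0.52 log units; beyond the scatter) and a 3.3-fold higher number from compound 2 to compound 4 (0.52 log units; beyond the scatter), both modest but beyond the scatter. Most of what the substituent contributes nevertheless survives this exchange, as a 30-fold lower number from compound 3 to compound 4 (1.48 log units; beyond the scatter) is large, so a pentyl chain joined through sulfur still stands far from the bare hydrogen of compound 3, though not level with the nitrogen-linked and oxygen-linked chains. No measurement available here explains why the sulfur-linked compound 4 parts from compound 1 and compound 2.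

The compounds shown hold the chain at pentyl throughout, so it stays open whether a shorter butyl chain or a longer hexyl chain would shift the sulfur-linked compound and the nitrogen-linked compound alike. On these data alone, it also stays open how a pentyl chain joined directly through carbon, or a sulfone in place of the sulfanyl link, would stand against these linkers.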